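Acid ceramidase series: aryl variation on the shared core

The source may report more compounds than this note shows. Statements on the series, on what has been measured and on what is new or still open speak of the compounds shown alone.

Measured so far:
compound 1 `O=c1[nH]cc(-c2ccccc2)o1`, "not active" (no number reported)
compound 2 `COc1cccc(-c2cn(C(=O)NCCCCc3ccccc3)c(=O)o2)c1`, 341 nM
compound 3 `Cn1nc(-c2cn(C(=O)NCCCCc3ccccc3)c(=O)o2)c2ccccc21`, 92 nM

In an assay on isolated protein for inhibition of acid ceramidase (Homo sapiens), read by LC-MS, with a stated time of 1 h (on this read-out lower numbers stand for stronger inhibition and higher numbers for weaker inhibition), compound 2 gives 341 nM, the highest of the two numbers in hand. Compound 3 sits at 92 nM, a step beyond the scatter from compound 2. Compound 1, which lacks the carbamoyl side chain, is recorded in this assay as "not active" (no number reported) with no number attached.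

Compound 4 `O=C(NCCCCc1ccccc1)n1cc(-c2nccs2)oc1=O` differs from compound 2 in one place: 1,3-thiazol-2-yl in place of 3-methoxyphenyl on an aromatic carbon. Among the measured compounds shown here, no measured pair covers this particular exchange, so the step can only be estimated. For the measured compounds named here, with only two numbers to lean on, and no comparable aryl-to-heteroaryl exchange measured, the expectation is a step of a 1.5-fold higher number from compound 2 to compound 4 (0.17 log units; within the scatter) in this assay, which is not expected to reach beyond the scatter in either direction. Compound 4 is therefore estimated at 500 nM, within a range from 150 nM to 1600 nM.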

Compound 4, half-maximal inhibitory concentration: 59 nM
The estimate for compound 4 lay 8.5-fold (0.93 log units) above the measured number; the measured number lies below the stated range.
By their numbers in this assay, from the lowest: compounds 4 and 3 (each within the scatter of the next); then compound 2.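

Working at the aromatic carbon next to the ring oxygen, the exchange of 3-methoxyphenyl for 1,3-thiazol-2-yl gives a 5.8-fold lower number from compound 2 to compound 4 (0.76 log units; beyond the scatter) in this assay and is the first single-place step read at this position. The number at this position thus does not depend on a six-membered aromatic ring of carbon only, since compound 4 with a five-membered aromatic ring with 2 hetero atoms reaches 59 nM in this series. No measurement in hand bears on what lies behind the size of this step.

One exchange alters ring size, ring nitrogen and ring sulfur together, and these remain unseparated; an unsubstituted phenyl, a 2-pyridyl or an oxazol-2-yl group at this place would pull them apart. Also open, on these data alone, is how the thiazolyl compound responds to a shorter or longer chain on the carbamoyl side.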